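Removing the nitro group from a benzyloxy aniline

The source may hold more compounds than are shown below. What is called first, only, known or untested is meant among the compounds shown, and "the series" means these compounds.

Measured so far:
compound 1 `O=[N+]([O-])c1ccc(COc2ccc(Nc3ncnc4cc5c(cc34)OCCOCCO5)cc2)cc1`, 8620 nM
compound 2 `FC(F)(F)c1ccc(COc2cccc(Nc3ncnc4cc5c(cc34)OCCOCCOCCO5)c2)cc1`, 24900 nM

Both compounds were tested in a functional assay on A549 cells (Homo sapiens) for antiproliferative activity, read by MTT assay, with a stated time of 72 h; a lower number here means a stronger inhibitor, a higher number a weaker inhibitor. Compound 1 gives the lower of the two numbers, and compound 2, which differs from it in several places at once, gives a number higher by a gap that lies beyond the usual scatter. Among the compounds with values here, compound 1 therefore stands as the better inhibitor of the pair, though only two compounds are known.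

Compound 3 `c1ccc(COc2ccc(Nc3ncnc4cc5c(cc34)OCCOCCO5)cc2)cc1` has not yet been measured. It differs from compound 1 in one place: hydrogen in place of nitro on an aromatic carbon. Within the data shown here, no measured pair shows a single change of this kind, so the size of the step must be guessed. The expectation for compound 3 is a modest change, if any, with a slight lean toward a weaker inhibitor, and the step from a 1.4-fold higher number from compound 1 to compound 3 (0.14 log units; within the scatter) is estimated to stay close to the scatter. Compound 3 is thus expected to give about 12000 nM, within a range of 4000 nM to 36000 nM.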

Compound 3, half-maximal inhibitory concentration: 43900 nM
Estimate against measurement, compound 3: 3.7-fold (0.56 log units) below, outside the stated range (above it).
By their numbers in this assay, from the lowest: compound 1; then compounds 2 and 3 (each within the scatter of the next).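

Hydrogen in place of nitro gives a 5.1-fold higher number from compound 1 to compound 3 (0.71 log units; beyond the scatter) in this assay. Within the data shown here, this is the first single change measured, and it shows that the substituent on this aromatic carbon, para to a large group, can shift the reading on its own, with nitro going with the lower number of this pair. The earlier comparison could not show this, as compound 1 and compound 2 differ in several places at once, and nothing at hand gives a reason for the step.

The compounds shown leave open whether another group on this carbon, such as an amine, a nitrile or a methoxy group, would give a number closer to that of compound 1 or to that of compound 3. They also leave open whether the step would keep its size on a different core, as compound 2 has no matching partner without its trifluoromethyl group.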